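The compounds below may be only part of what the source reports. "The series", "measured", "known", "first", "only" and "open" are said of these compounds alone.

Working notes on the series. For the measured compounds named here, compound 3 `O=C(NCc1ccc(CNS(=O)(=O)c2ccc3c(c2)CCO3)cc1)c1scc2c1OCCO2` gives 10 nM in an assay on cells for displacement of a labelled ligand from C-X-C chemokine receptor type 4 (Homo sapiens), read by fluorescence and microscopy, with stated times of 10 min and 30 min (a higher number here means that more compound is needed for the effect, a lower number that less compound is needed), which places it second highest of the three numbers measured so far. Compound 1 `O=C(NCc1ccc(CNS(=O)(=O)c2ccc3c(c2)CCO3)cc1)c1cccc2c1COC2` gives 1000 nM in this assay, and compound 2 `O=C(NCc1ccc(CNS(=O)(=O)c2ccc(F)cc2F)cc1)c1cncnc1` gives 1 nM. Going by the values given here, the one step recorded at the carbonyl carbon is a 100-fold lower number from compound 1 to compound 3 (2.00 log units; beyond the scatter), which shows that the amide-borne group can move the number a long way. Among the compounds with values here, compound 2 carries a different sulfonamide aryl as well, so no step to it is counted; its value only shows that a small six-membered heteroaryl on the carbonyl carbon can sit low in this assay.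

Compound 4 `O=C(NCc1ccc(CNS(=O)(=O)c2ccc3c(c2)CCO3)cc1)c1cccnc1` differs from compound 3 as follows: a group of 6 heavy atoms (5 carbon, 1 nitrogen; one six-membered aromatic ring with 1 hetero atom) in place of a group of 9 heavy atoms (6 carbon, 2 oxygen, 1 sulfur; one five-membered aromatic ring with 1 hetero atom, one six-membered non-aromatic ring with 2 hetero atoms), on a carbonyl carbon. The change is at the same place as the large step recorded from compound 1 to compound 3, so a step beyond the scatter in either direction is plausible. On balance the expectation is a modest rise, estimated as a 2.5-fold higher number from compound 3 to compound 4 (0.40 log units; beyond the scatter). Compound 4 is expected to give 25 nM in this assay, with a range of 2.5 nM to 250 nM.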

Compound 4, effective concentration (reported as EC, without a stated level of effect): 1000 nM
The estimate for compound 4 lay 40-fold (1.60 log units) below the measured number; measured number above the stated range.
By their numbers in this assay, from the lowest: compound 2; then compound 3; then compounds 1 and 4 (each within the scatter of the next).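

At the carbonyl carbon, the low number of compound 3 does not carry over to every ring group: the exchange for pyridin-3-yl gives a 100-fold higher number from compound 3 to compound 4 (2.00 log units; beyond the scatter) in this assay, a step of the same printed size as the earlier one but in the opposite direction. Pyridin-3-yl and the group carried by compound 1 give no change at the digits printed from compound 1 to compound 4 (within the scatter), so among the three amides sharing this sulfonamide, only the group of compound 3 stands apart. Nothing on hand bears on the reason for this difference.

Which part of the group of compound 3 goes with the low number remains open, as does whether a phenyl group or a carboxylic acid on the carbonyl carbon would align with compound 3 or with compounds 1 and 4. From the compounds shown here alone, compound 2 differs from the others in two places, so its steps cannot be read, and the effect of pyridin-3-yl alongside its 2,4-difluorophenyl sulfonamide also remains open.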